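Benzyl aryl swap on the shared core: compound 4

The source may hold more compounds than are shown below. What is called first, only, known or untested is meant among the compounds shown, and "the series" means these compounds.

Measured so far in a functional assay on U-251 cells (Homo sapiens) for inhibition, read by sulforhodamine B assay, with a stated time of 48 h; on this read-out lower numbers stand for stronger inhibition of growth and higher numbers for weaker inhibition of growth:
Compound 1, `Nc1cc(N)c2nc(-c3ccccc3)c(NCc3ccc(Cl)c(Cl)c3)nc2c1`, gives 2090 nM.
Compound 2, `Nc1cc(N)c2nc(-c3ccccc3)c(Sc3ccc(F)cc3)nc2c1`, gives 16200 nM.
Compound 3, `Nc1cc(N)c2nc(-c3ccccc3)c(Oc3ccc(F)cc3)nc2c1`, gives 23400 nM.

Compound 1 stands lowest of the three numbers; compound 2 and compound 3 both give higher numbers, each beyond the scatter from compound 1. Within the data shown here, the only single-point step among the measured compounds is a 1.4-fold higher number from compound 2 to compound 3 (0.16 log units; within the scatter), which concerns the link between the core and the fluorophenyl group, not the benzylamine side chain.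

Compound 4, `COc1ccc(CNc2nc3cc(N)cc(N)c3nc2-c2ccccc2)cc1`, is not yet measured. It differs from compound 1 by 4-methoxyphenyl in place of 3,4-dichlorophenyl on a saturated chain carbon bound to a nitrogen on an aromatic ring. Among the measured compounds shown here, no measured step touches this benzyl aryl group, so the direction of the step rests on the replacement alone. The 3,4-dichlorophenyl of compound 1 gives the lowest number seen; its exchange for 4-methoxyphenyl is expected to cost some of that, with a step of moderate size toward a higher number, though a result within the scatter cannot be excluded.

Compound 4 is therefore estimated at 5000 nM, with a range of 1500 nM to 16000 nM in this assay . This estimate means an expected step of a 2.4-fold higher number from compound 1 to compound 4 (0.38 log units; beyond the scatter).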

Compound 4, concentration for 50% growth inhibition: 13500 nM
Compound 4: the middle estimate sits 2.7-fold (0.43 log units) below what was measured; low and high end bracket the measured number.
By their numbers in this assay, from the lowest: compound 1; then compounds 4, 2 and 3 (each within the scatter of the next).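

In this assay, the benzyl aryl group is a place where a single exchange moves the number beyond the scatter: a 6.5-fold higher number from compound 1 to compound 4 (0.81 log units; beyond the scatter). The 4-methoxyphenyl and 3,4-dichlorophenyl groups have the same heavy-atom count, so this step does not come with a change in that count, although the entering group carries a hydrogen-bond acceptor that the leaving group lacks. No evidence on the cause of this step is available.

The compounds shown do not separate loss of the chlorines from arrival of the methoxy group, and an unsubstituted phenyl group or a trifluoromethyl group on the same chain carbon would bear on that question. The effect of the amine link also remains open, since no pair shown changes that link while keeping the same aryl group.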